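The source may hold more compounds than are shown below. What is called first, only, known or untested is meant among the compounds shown, and "the series" means these compounds.

Compound 1 `COC(=O)[C@H]1C[C@@H](c2coc3ccccc3c2=O)N(c2ccccc2)O1`: in a functional assay on PC-3 cells (Homo sapiens) for inhibition, read by sulforhodamine B assay, with a stated time of 48 h (a higher number here means a weaker inhibitor, a lower number a stronger inhibitor), compound 1 gives > 60000 nM, a limit of the assay rather than a number.
Compound 2 `CCO[C@H]1C[C@@H](c2coc3ccccc3c2=O)N(c2ccccc2)O1`: in this assay compound 2 gives > 60000 nM, again a limit of the assay.
Compound 3 `O=c1c([C@@H]2C[C@H](c3ccccc3)ON2c2ccccc2)coc2ccc(Br)cc12`: in this assay compound 3 gives 60000 nM.

Compound 3 is thus the only one of the three with a measured number; the other two sit at a limit, as the line the limit of > 60000 nM in this assay, at which 2 of the 3 values shown sit, shows. Among the compounds with values here, the single step between measured compounds, a step that the two limits leave unreadable from compound 1 to compound 2, cannot be read, so there is no measured step in which bromo is swapped for anything.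

Compound 4 `O=c1c([C@@H]2C[C@H](c3ccccc3)ON2c2ccccc2)coc2ccccc12` differs from compound 3 by hydrogen in place of bromo on an aromatic carbon. Within the data shown here, no measured step bears on this change, so the only guide is where compound 3 itself stands, close to the top of the range that this assay reports. The step from compound 3 to compound 4 is therefore expected to be no change at the digits printed from compound 3 to compound 4 (within the scatter), no clearer than the scatter in either direction. For compound 4 the estimate in this assay is 60000 nM, within the range 25000 nM to 150000 nM, with a fair chance that only a limit is reported.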

Compound 4, half-maximal inhibitory concentration: > 60000 nM
Compound 4 ended at the assay's limit; the forecaster's own chance of this, stated with the estimate: 55%; the middle value sits exactly at the limit.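

In this assay, replacing bromo with hydrogen gives a number no lower from compound 3 to compound 4 (the limit leaves the size open). This is the first step among these compounds with a readable direction: removing bromo from this aromatic carbon does not produce a stronger inhibitor, although whether the compound becomes weaker at all, and by how much, stays open. The steps to compound 4 from compound 1 and from compound 2 cannot be read, and the values now gather at one end of the scale: the limit of > 60000 nM in this assay, at which 3 of the 4 values shown sit.

The compounds shown leave open whether an amine, a methoxy group or a carboxylic acid on this aromatic carbon would give a number clearly lower than that of compound 3. Within the data shown here, they also leave open how much bromo itself contributes, since the only number here belongs to compound 3 and no comparison yet measures its effect in size.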